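A Side-Chain Branch Carried Onto a Second Core

This account rests on a few compounds, and the source may have more. Where it says the series, first, only, none or still open, it means among the compounds named here.

Compound 1 `COC(=O)NCCOc1ccc(Cl)cc1C(=O)N[C@H](C(=O)Nc1ccc([N+](=O)[O-])cc1Cl)C(C)C` gives > 10000 nM in a functional assay on MDA-MB-231 cells (Homo sapiens) for inhibition, read by MTT assay, with a stated time of 72 h (a higher number here means a weaker inhibitor, a lower number a stronger inhibitor), which is a limit of the assay and not a number.
Compound 2 `CC(C)COC(=O)NCCOc1ccc(Cl)cc1C(=O)N[C@H](C(=O)Nc1ccc([N+](=O)[O-])cc1Cl)C(C)C` gives 4900 nM in this assay.
Compound 3 `C[C@H](NC(=O)c1cc(Cl)ccc1OCCNC(=O)OC(C)(C)C)C(=O)Nc1ccc([N+](=O)[O-])cc1Cl` gives > 10000 nM in this assay, again a limit and not a number.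

Within the data shown here, the one measured step is isopropyl in place of hydrogen on a saturated chain carbon bound to an oxygen next to a carbonyl group, and it reads an at least 2.0-fold lower number from compound 1 to compound 2 (0.30 log units; that floor lies within the scatter). Its size is bounded only from one side, due to the limit of > 10000 nM in this assay, at which 2 of the 3 values shown sit. How the core of compound 3 differs from the core of compound 1 is not broken down here.

Compound 4 `CC(C)C[C@H](NC(=O)c1cc(Cl)ccc1OCCNC(=O)OC(C)(C)C)C(=O)Nc1ccc([N+](=O)[O-])cc1Cl` is not yet measured. It differs from compound 3 by isopropyl in place of hydrogen on a saturated chain carbon, two bonds along the chain from an amide-type nitrogen and a carbonyl carbon. The place is not the same as in the step from compound 1 to compound 2, where the carbon is bound to an oxygen next to a carbonyl group rather than two bonds along the chain from an amide-type nitrogen and a carbonyl carbon, so this is the same kind of change, not the same change.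

Compound 4 is expected to show an at least 1.4-fold lower number from compound 3 to compound 4 (0.15 log units; that floor lies within the scatter), set beside an at least 2.0-fold lower number from compound 1 to compound 2 (0.30 log units; that floor lies within the scatter), because that measured step started from the limit that compound 3 also sits at, as the limit of > 10000 nM in this assay, at which 2 of the 3 values shown sit, records. The estimate for compound 4 is 7000 nM, expected to lie between 2500 nM and 20000 nM.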

Compound 4, half-maximal inhibitory concentration: > 10000 nM
Compound 4 ended at the assay's limit (the forecaster's own chance of this, stated with the estimate: 45%); middle value at least 1.4-fold (0.15 log units) from the limit.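

Compound 3 and compound 4 both sit at a limit and not at a number, so no step can be read between them: the limit of > 10000 nM in this assay, at which 3 of the 4 values shown sit.

The compounds shown leave open whether isopropyl in place of hydrogen at this place changes the result in this assay on this core at all, since any such change would lie beyond the limit.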